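The source may report more compounds than this note shows. Statements on the series, on what has been measured and on what is new or still open speak of the compounds shown alone.

Working notes on the anilino-substituted series sharing one core.

Among the compounds with values here, compound 1 `CCCc1ccc(NC2=CC(=O)c3c(nc4n3[C@H]3OC[C@@H](O)[C@H]3OC4)C2=O)cc1` is the first of two measured members. In a functional assay on HeLa cells (Homo sapiens) for inhibition, read by sulforhodamine B assay (a higher number here means a weaker inhibitor, a lower number a stronger inhibitor), compound 1 gives 6030 nM. Compound 2 `CCCc1ccc(NC2=CC(=O)c3nc4n(c3C2=O)[C@H]2OC[C@@H](O)[C@H]2OC4)cc1` carries the same 4-propylphenyl group on a closely related core, and in this assay compound 2 gives 4990 nM. The two numbers sit close together, within the usual scatter of the method, so compound 1 cannot be placed ahead of or behind compound 2 on these values; it simply stands at the upper of the two numbers shown, with the gap too small to carry any meaning.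

Compound 3 `CCc1ccc(NC2=CC(=O)c3c(nc4n3[C@H]3OC[C@@H](O)[C@H]3OC4)C2=O)cc1` is not yet measured. Against compound 1 the difference is hydrogen in place of methyl on a saturated chain carbon, two bonds along the chain from an aromatic carbon. The change shortens the chain by a single carbon on the aryl substituent, with no ring, donor or acceptor involved. Within the data shown here, no measured pair tracks this change, so no step can be quoted for it. With compound 1 at 6030 nM, the step from compound 1 to compound 3 is expected to be small, most likely within the scatter, with a slight lean toward a higher number: a 1.2-fold higher number from compound 1 to compound 3 (0.09 log units; within the scatter). Compound 3 is therefore estimated at 7500 nM, with a range from 3000 nM to 18000 nM.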

Compound 3, half-maximal inhibitory concentration: 6510 nM
Beside the measured number, compound 3's estimate is 1.2-fold (0.06 log units) above it, within the range that was stated.
By their numbers in this assay, from the lowest: compounds 2, 1 and 3 (each within the scatter of the next).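

In this assay the change from 4-propylphenyl to 4-ethylphenyl, hydrogen in place of methyl on a saturated chain carbon, gives a 1.1-fold higher number from compound 1 to compound 3 (0.03 log units; within the scatter) and so does not move the reading beyond the scatter on the core of compound 1. Within the data shown here, this is the first direct read on the aryl substituent of the series, since the earlier values offered no pair in which the chain alone differed, and it shows that this one-carbon difference at the chain end cannot be separated from noise at this level of inhibition. Nothing available on these compounds bears on this result or accounts for it.

A single pair fixes only the propyl and ethyl ends of the question, so it gives no trend along the chain and does not show whether the same holds on the core of compound 2. Open too, going by these compounds, is how the number would respond to a substantially different group in place of propyl, such as a longer chain like hexyl, a terminal amine or a carboxylic acid, or to a bare phenyl with no chain at all.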